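This account rests on a few compounds, and the source may have more. Where it says the series, first, only, none or still open, it means among the compounds named here.

Of the compounds shown here, two from this series have been tested in a functional assay on 3T3-L1 cells (Mus musculus) for inhibition, with a stated time of 20 min, tested at 20 uM; a higher number here means more inhibition at the concentration tested (going by the name of the read-out), a lower number less inhibition. Compound 1, whose structure is `Cc1ccc(S(=O)(=O)N(Cc2cn(Cc3ccccc3Cl)nn2)Cc2cn(S(=O)(=O)c3ccc(C)cc3)c3ccccc23)cc1`, gives -4.8% in this assay. Compound 2, with the structure `Cc1ccc(S(=O)(=O)n2cc(CN(Cc3cn(Cc4ccc(F)cc4)nn3)S(C)(=O)=O)c3ccccc32)cc1`, gives -19.5% in this assay. Compound 1 therefore stands highest of the two numbers, and compound 2 sits lower by a margin that is beyond the scatter of the assay, though neither value signals appreciable inhibition.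

The next compound, compound 3, has the structure `Cc1ccc(S(=O)(=O)N(Cc2cn(Cc3ccccc3)nn2)Cc2cn(S(=O)(=O)c3ccc(C)cc3)c3ccccc23)cc1`. It differs from compound 1 in one place only: hydrogen in place of chloro on an aromatic carbon.

No step between measured compounds matches this change, so there is nothing shown here to set its size. Given that compound 1 gives -4.8% in this assay, compound 3 is expected to fall close to it, with a step of a number 0.2 percentage points lower from compound 1 to compound 3 (within the scatter) that is not expected to exceed the scatter. The estimate for compound 3 in this assay is -5%, with a range from -20% to 10%.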

Compound 3, a percentage reported as inhibition, at one concentration (the size of the read-out at that concentration, not a potency): 3.4%
Compound 3: the middle estimate sits 8.4 percentage points below what was measured; low and high end bracket the measured number.
By their numbers in this assay, from the lowest: compound 2; then compounds 1 and 3 (each within the scatter of the next).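

Going by these compounds alone, replacing chloro with hydrogen on an aromatic carbon ortho to a large group, which turns 2-chlorobenzyl into benzyl, gives the first direct reading of this position in this assay: a number 8.2 percentage points higher from compound 1 to compound 3 (within the scatter). Compound 1 and compound 3 therefore cannot be told apart in this assay, so this pair does not show that the chloro group matters there, and compound 3, at 3.4%, does not show appreciable inhibition. Nothing available explains the size of this step.

Going by these compounds, it remains open whether methoxy, an amine or a carboxylic acid in place of chloro at this position would shift the number beyond the scatter. On these data alone, it is also open whether any such replacement would give appreciable inhibition at the concentration tested.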